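The compounds below may be only part of what the source reports. "The series", "measured", "known", "first", "only" and "open" are said of these compounds alone.

Working notes on the series, read in a physicochemical assay for solubility, in phosphate buffer, measured as thermodynamic solubility, at pH 2; a higher number here means a more soluble compound, a lower number a less soluble compound. Compound 1 (`NC1CCN(c2nc3c(c(Nc4ccc(C(F)(F)F)cc4)n2)CCN(c2ncccc2C(F)(F)F)CC3)C1`) stands at > 215 ug/mL in this assay and this is a limit, not a number. Compound 2 (`FC(F)(F)c1ccc(Nc2nc(N3CCN(C4CCC4)CC3)nc3c2CCN(c2ncccc2C(F)(F)F)CC3)cc1`) stands at > 237 ug/mL in this assay and this too is only a limit, so compound 2 has no exact position in the series.

Compound 3 (`CN1CCCCC1CNc1nc2c(c(Nc3ccc(C(F)(F)F)cc3)n1)CCN(c1ncccc1C(F)(F)F)CC2`) carries ((1-methylpiperidin-2-yl)methyl)amino in place of 4-cyclobutylpiperazin-1-yl on an aromatic carbon.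

Going by the values given here, one measured step bears on this change, a replacement at the same aromatic carbon: a step that the two limits leave unreadable from compound 1 to compound 2 has no readable size. It gives no basis for a move in either direction, so no shift beyond the scatter is expected in this assay, and compound 3 may well read as a limit again. The expected step is a step that the limit leaves unreadable from compound 2 to compound 3 and this is an estimate only.

For compound 3 the estimated solubility is 240 ug/mL (expected range 120 ug/mL to 420 ug/mL).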

Compound 3, solubility: > 277 ug/mL
Compound 3: a limit, no number; the forecaster's own chance of this, stated with the estimate: 70%; middle value at least 1.1-fold (0.06 log units) from the limit.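

In this assay compound 3 gives > 277 ug/mL, which is a limit and not a number. Going by these compounds alone, compound 2 gives > 237 ug/mL, also a limit, and no step among compound 1, compound 2 and compound 3 can be read. Going by these compounds, the exact solubility of all three, and whether the three groups on the aromatic carbon differ at all in this assay, stay open.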